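This account rests on a few compounds, and the source may have more. Where it says the series, first, only, none or still open, it means among the compounds named here.

Working notes on the series, read in a functional assay on FM3A cells (Mus musculus) for cytotoxicity; on this read-out higher numbers stand for an effect only at larger amounts of compound and lower numbers for an effect already at smaller amounts. Compound 1 `c1ccc(C2OOC3CCCC(c4ccccc4)(OO2)O3)cc1` gives 50000 nM, compound 3 `CCC(CC)C1OOC2CCCC(c3ccccc3)(OO1)O2` gives 33000 nM, and compound 2 `c1ccc(C23CCCC(OOC(C4CCCCC4)OO2)O3)cc1` gives 10000 nM. Compound 2 holds the lowest number of the three, and its steps to both others lie beyond the scatter.

Compound 4 `Fc1ccc(C23CCCC(OOC(C4CCCCC4)OO2)O3)cc1` is compound 2 with a single change: fluoro in place of hydrogen on an aromatic carbon. This is fluoro in place of hydrogen on an aromatic carbon, para to a large group.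

Among the measured compounds shown here, no measured step places a substituent on an aromatic carbon, so the evidence is only indirect. All three steps exchange a group on a saturated ring carbon. The measured steps are a 5.0-fold lower number from compound 1 to compound 2 (0.70 log units; beyond the scatter) and a 3.3-fold higher number from compound 2 to compound 3 (0.52 log units; beyond the scatter), both modest, and a 1.5-fold lower number from compound 1 to compound 3 (0.18 log units; within the scatter), which stays within the scatter. Since even these exchanges of a larger group give only modest steps, no step beyond the scatter is expected in this assay for the smaller change here, and no direction can be argued from the data.

The estimated step is a 1.1-fold lower number from compound 2 to compound 4 (0.05 log units; within the scatter). For compound 4 the expected value is 9000 nM, with an estimated range from 4000 nM to 22000 nM.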

Compound 4, half-maximal effective concentration: 2500 nM
The estimate for compound 4 lay 3.6-fold (0.56 log units) above the measured number; the whole stated range lies above it.
By their numbers in this assay, from the lowest: compound 4; then compound 2; then compounds 3 and 1 (each within the scatter of the next).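

The aromatic carbon para to a large group responds to a single fluoro in this assay, since phenyl to 4-fluorophenyl gives a 4.0-fold lower number from compound 2 to compound 4 (0.60 log units; beyond the scatter) and shows that this part of the molecule is not silent. Among the compounds shown here, all the earlier steps exchanged a group on a saturated ring carbon, so this is the first reading on the aromatic ring, and one heavy atom here gives a modest step of the same class as the exchange of a whole group in a 5.0-fold lower number from compound 1 to compound 2 (0.70 log units; beyond the scatter) on the saturated ring carbon. The data shown offer no measured basis for explaining this step.

Still open, from the compounds shown here alone, is whether the step belongs to fluoro itself or would also appear with another group on the same carbon, such as chloro, methoxy, an amine or a carboxylic acid. Also open, going by these compounds, is whether the 4-fluorophenyl gain carries over when the cyclohexyl of compound 4 gives way to the pentan-3-yl of compound 3 or the phenyl of compound 1, and whether the other carbons of the aromatic ring respond in the same way.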